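A Hydroxy Group Replaces the Pyrrolyl on the Shared Core

The compounds below may be only part of what the source reports. "The series", "measured", "known", "first", "only" and "open" are said of these compounds alone.

Compound 1 `CC1(C)C=C(n2ccccc2=O)c2ccccc2O1`: 5.43
Compound 2 `Cc1ccc(C)n1-c1ccc2c(c1)C(n1ccccc1=O)=CC(C)(C)O2`: 7.27

Both compounds were tested in a functional assay (aorta) with Rattus norvegicus as the target; on this read-out lower numbers stand for lower potency and higher numbers for higher potency (the scale is a negative logarithm). Compound 2 holds the higher of the two numbers, and the step of a number 1.84 log units higher from compound 1 to compound 2 (beyond the scatter) separates it from compound 1. Compound 3 `CC1(C)C=C(n2ccccc2=O)c2cc(O)ccc2O1` differs from compound 2 in one place: hydroxy in place of 2,5-dimethyl-1H-pyrrol-1-yl on an aromatic carbon. For the measured compounds named here, only the step from compound 1 to compound 2 bears on this change, as it shows what the 2,5-dimethyl-1H-pyrrol-1-yl group contributed on that aromatic carbon; its size was a number 1.84 log units higher from compound 1 to compound 2 (beyond the scatter), beyond the scatter. Going by the values given here, no measured compound carries hydroxy at this position, so how far hydroxy departs from hydrogen there is unknown. Removing the pyrrolyl is therefore expected to give back most of that gain, with a number 1.47 log units lower from compound 2 to compound 3 (beyond the scatter) as the expected step. The estimate for compound 3 in this assay is 5.8, with a range from 5 to 6.8.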

Compound 3, logarithm of the reciprocal of the active concentration, log(1/C): 5.44
For compound 3 the middle estimate is 0.36 log units above the measured one, within the range that was stated.
By their numbers in this assay, from the lowest: compounds 1 and 3 (each within the scatter of the next); then compound 2.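

In this assay, hydroxy and hydrogen on this aromatic carbon cannot be told apart, with a number 0.01 log units higher from compound 1 to compound 3 (within the scatter). The gain carried by 2,5-dimethyl-1H-pyrrol-1-yl therefore does not survive this exchange, with a number 1.83 log units lower from compound 2 to compound 3 (beyond the scatter), so among these three compounds only that group sets the number apart at this position. Nothing available here explains this difference between the groups.

The compounds shown leave open which part of 2,5-dimethyl-1H-pyrrol-1-yl matters, since a pyrrol-1-yl group without the two methyl groups does not appear among them. They also leave open how an amine, a methoxy group or a phenyl ring would compare on the same aromatic carbon of the shared core.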